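A few compounds are considered here, and "the series" means these few. Any claim that something is new, unique, unknown or untested is made for them only; others in the source may bear on it.

Measured so far in an assay on a protein complex for displacement of a labelled ligand from CDK8/Cyclin C (Homo sapiens), read by TR-FRET, with a stated time of 1 h; a higher number here means a weaker inhibitor, a lower number a stronger inhibitor:
compound 1, `CNc1nccc(N2CC[C@H](NC(=O)Nc3cccc(C#N)c3)C2)n1`: 3480 nM
compound 2, `CNc1nccc(N2CC[C@H](NC(=O)Nc3ccc(OC)cc3)C2)n1`: 7160 nM
compound 3, `CNc1nccc(N2CC[C@H](NC(=O)Nc3ccc(OC(F)(F)F)cc3)C2)n1`: 44.1 nM

Compound 3 gives the lowest of these three numbers and is therefore the strongest inhibitor of the set in this assay; compound 1 stands nearest to it and compound 2 furthest. Compound 4, `CNc1nccc(N2CC[C@H](NC(=O)Nc3ccc(OC(F)F)cc3)C2)n1`, differs from compound 3 by hydrogen in place of fluoro on a saturated chain carbon bound to two fluorine atoms and an oxygen on an aromatic ring. For the measured compounds named here, no measured step repeats this exact change. The step that bears on it is the one on the same oxygen, a 160-fold lower number from compound 2 to compound 3 (2.21 log units; beyond the scatter), where methyl became trifluoromethyl. Going from trifluoromethyl to difluoromethyl undoes a fraction of that change, so compound 4 is expected to sit between compound 2 and compound 3, much nearer compound 3. The estimate for compound 4 is 120 nM, with a range from 40 nM to 400 nM. The step this expectation means is a 2.7-fold higher number from compound 3 to compound 4 (0.43 log units; beyond the scatter).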

Compound 4, half-maximal inhibitory concentration in the CDK8/Cyclin C assay: 143 nM
Estimate against measurement, compound 4: 1.2-fold (0.08 log units) below; low and high end bracket the measured number.
By their numbers in the CDK8/Cyclin C assay, from the lowest: compound 3; then compound 4; then compound 1; then compound 2.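

In the CDK8/Cyclin C assay, compound 2 gives 7160 nM, compound 3 gives 44.1 nM and compound 4 gives 143 nM. Trifluoromethyl to difluoromethyl on this oxygen gives a 3.2-fold higher number from compound 3 to compound 4 (0.51 log units; beyond the scatter), while difluoromethyl in place of methyl gives a 50-fold lower number from compound 2 to compound 4 (1.70 log units; beyond the scatter). So on this oxygen, most of the drop from the methyl compound is already reached with two fluorine atoms, and the third adds a smaller further drop. In a physicochemical assay for solubility, measured as kinetic solubility (a higher number here means a more soluble compound, a lower number a less soluble compound), compound 3 gives 70400 nM and compound 4 gives 92800 nM. The same change gives a 1.3-fold higher number from compound 3 to compound 4 (0.12 log units; within the scatter), so solubility does not separate the pair.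

The data offer no measurement that explains these differences. From the compounds shown here alone, whether monofluoromethyl or a longer chain such as ethyl on this oxygen would give a low number remains open.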